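Swapping the aryl group on the oxazole core

The source may report more compounds than this note shows. Statements on the series, on what has been measured and on what is new or still open speak of the compounds shown alone.

Of the compounds shown here, three sharing one core have been tested in an assay (Rattus norvegicus) for inhibition of Fatty-acid amide hydrolase 1 (Homo sapiens); on this read-out lower numbers stand for stronger inhibition and higher numbers for weaker inhibition. Compound 1 `O=C(CCCCCCc1ccccc1)c1ncc(-c2ccccc2F)o1` carries a 2-fluorophenyl group and gives 110 nM. Compound 2 `NC(=O)c1cccc(-c2cnc(C(=O)CCCCCCc3ccccc3)o2)c1` carries a 3-carbamoylphenyl group and gives 6 nM. Compound 3 `O=C(O)c1ccc(-c2cnc(C(=O)CCCCCCc3ccccc3)o2)cc1` carries a 4-carboxyphenyl group and gives 60 nM, which places it second highest of the three numbers: its nearest neighbour is compound 1, with a 1.8-fold lower number from compound 1 to compound 3 (0.26 log units; within the scatter), while a 10-fold higher number from compound 2 to compound 3 (1.00 log units; beyond the scatter) separates it from compound 2 by a gap beyond the scatter.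

Compound 4 `Cc1ccc(-c2cnc(C(=O)CCCCCCc3ccccc3)o2)nc1` has not been measured yet. It differs from compound 3 in one place: 5-methylpyridin-2-yl in place of 4-carboxyphenyl on an aromatic carbon.

Going by the values given here, the steps that bear on this change are those that swap the same group on the same aromatic carbon of the core. They range from the small 1.8-fold lower number from compound 1 to compound 3 (0.26 log units; within the scatter) to the large 18-fold lower number from compound 1 to compound 2 (1.26 log units; beyond the scatter), so a change at this position can shift the number anywhere from within the scatter to beyond it. The new group resembles neither a carboxyphenyl nor a carbamoylphenyl, so its effect in this assay is uncertain. Still, a move toward stronger inhibition is more likely than the reverse given how readily this position tolerates variation.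

Compound 4 is therefore expected to show a step of a 3.0-fold lower number from compound 3 to compound 4 (0.48 log units; beyond the scatter). The estimate for compound 4 in this assay is 20 nM, with a range from 5 nM to 80 nM.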

Compound 4, inhibition constant: 2.8 nM
Compound 4: the middle estimate sits 7.1-fold (0.85 log units) above what was measured; the whole stated range lies above it.
By their numbers in this assay, from the lowest: compound 4; then compound 2; then compounds 3 and 1 (each within the scatter of the next).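

In this assay, going by these compounds alone, this position on the shared core can give more than the earlier compounds showed: 5-methylpyridin-2-yl brings a 21-fold lower number from compound 3 to compound 4 (1.33 log units; beyond the scatter) and a 39-fold lower number from compound 1 to compound 4 (1.59 log units; beyond the scatter), and it also goes beyond the best earlier group, with a 2.1-fold lower number from compound 2 to compound 4 (0.33 log units; beyond the scatter). Compound 4 now has the lowest number of the four, so the hydrogen-bond donor that leaves with 4-carboxyphenyl is not needed for a low number in this set, and an aromatic ring with a hetero atom works well at this carbon. The data shown offer nothing that explains why this swap has so large an effect.

The new group differs from the earlier ones in both its ring nitrogen and its methyl, so the compounds shown cannot divide the gain between the two; a pyridine ring without the methyl and a phenyl ring carrying only a methyl would separate them. As far as these compounds go, all four compounds also share the same phenyl-ended chain on the carbonyl, so it remains open whether this order of aryl groups would hold with a shorter chain.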